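Carbamate replaces urea on the ring amide carbonyl

The source may report more compounds than this note shows. Statements on the series, on what has been measured and on what is new or still open speak of the compounds shown alone.

Measured compounds:
compound 1 `CC(C)C(=O)N1C[C@@H](C)N(c2ncc3[nH]nc(-c4ccc(N5CCN[C@H](C)C5)nc4)c3n2)[C@@H](C)C1`: an assay on HeLa cells for inhibition of activin receptor type-1 (Homo sapiens), read by HTRF, with stated times of 1 h and 30 min (a higher number here means a weaker inhibitor, a lower number a stronger inhibitor), 661 nM
compound 2 `C[C@@H]1CN(c2ccc(-c3n[nH]c4cnc(N5[C@H](C)CN(C(=O)N(C)C)C[C@@H]5C)nc34)cn2)CCN1`: 350 nM in this assay

The two measured compounds share one core and differ only at the group on the carbonyl carbon of the ring amide: an isopropyl in compound 1, a dimethylamino in compound 2. For the measured compounds named here, the single step between them is a 1.9-fold lower number from compound 1 to compound 2 (0.28 log units; within the scatter). Going by the values given here, compound 2 thus holds one of only two numbers, and its sole neighbour, compound 1, sits within the scatter of it, so the two cannot be told apart on these data.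

Compound 3 `CCOC(=O)N1C[C@@H](C)N(c2ncc3[nH]nc(-c4ccc(N5CCN[C@H](C)C5)nc4)c3n2)[C@@H](C)C1` keeps everything else and changes the same position: ethoxy in place of dimethylamino on a carbonyl carbon. Among the compounds with values here, the only measured step that bears on this carbonyl carbon is a 1.9-fold lower number from compound 1 to compound 2 (0.28 log units; within the scatter), and it stayed within the scatter. With exchanges at this place having moved the number so little, no step beyond the scatter is expected in either direction in this assay. For compound 3 the estimate is 420 nM, with a range from 180 nM to 950 nM. For compound 3 this corresponds to an expected step of a 1.2-fold higher number from compound 2 to compound 3 (0.08 log units; within the scatter).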

Compound 3, half-maximal inhibitory concentration: 212 nM
The estimate for compound 3 lay 2.0-fold (0.30 log units) above the measured number, and the stated range covers the measured number.
By their numbers in this assay, from the lowest: compounds 3, 2 and 1 (each within the scatter of the next, the first and the last beyond it).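

In this assay, putting ethoxy in place of dimethylamino on the carbonyl carbon gives a 1.7-fold lower number from compound 2 to compound 3 (0.22 log units; within the scatter) and so leaves compound 2 and compound 3 indistinguishable. For the compounds shown here, the new information comes from the comparison with isopropyl, a 3.1-fold lower number from compound 1 to compound 3 (0.49 log units; beyond the scatter) and the first exchange at this place to pass beyond the scatter, although only modestly; this position therefore does respond to the group on the carbonyl carbon, even though compound 2 remains within the scatter of both of the others. Nothing available explains why ethoxy and isopropyl differ here.

From the compounds shown here alone, it remains open whether a longer chain such as butoxy, a branched group such as tert-butoxy, or a ring amine such as morpholine on this same carbonyl carbon would lower the number further or raise it again. Going by these compounds alone, with only three compounds on one shared core, it also remains open whether the step from isopropyl to ethoxy would hold with a different group elsewhere on the molecule.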